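Acyl group swap at the amide of compound 2

This account rests on a few compounds, and the source may have more. Where it says the series, first, only, none or still open, it means among the compounds named here.

Compound 2 `O=C(NCc1ccc(CNS(=O)(=O)c2ccc3c(c2)CCO3)cc1)c1scc2c1OCCO2` stands highest of the two measured numbers: in an assay on cells for inhibition of C-X-C chemokine receptor type 4 (Homo sapiens), with a stated time of 22 h, tested at 100 nM (a lower number here means less inhibition, a higher number more inhibition at the concentration tested (going by the name of the read-out)), compound 2 gives 68%, while compound 1 `O=C(NCc1ccc(CNS(=O)(=O)c2ccccc2F)cc1)c1cc2ccccn2n1` gives 40%, a gap beyond the usual scatter. Within the data shown here, compound 1 and compound 2 differ in more than one place, so no single structural step can be drawn between them. Compound 3 `Cn1nccc1C(=O)NCc1ccc(CNS(=O)(=O)c2ccc3c(c2)CCO3)cc1` has not yet been measured in this assay. It differs from compound 2 as follows: a group of 6 heavy atoms (4 carbon, 2 nitrogen; one five-membered aromatic ring with 2 hetero atoms) in place of a group of 9 heavy atoms (6 carbon, 2 oxygen, 1 sulfur; one five-membered aromatic ring with 1 hetero atom, one six-membered non-aromatic ring with 2 hetero atoms), on a carbonyl carbon. Nothing measured here isolates what the group on the carbonyl carbon contributes, and compound 1 carries a different acyl group together with a different sulfonyl group. A loss beyond the scatter seems more likely than a gain, as the group leaving is counted larger than the group entering, but the data do not settle it; the step expected is a number 23 percentage points lower from compound 2 to compound 3 (beyond the scatter). Compound 3 is estimated to give 45%, with a range from 20% to 70%.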

Compound 3, a percentage reported as inhibition, at one concentration (the size of the read-out at that concentration, not a potency): 40%
Compound 3: middle estimate off by 5 percentage points, on the high side; measured number inside the range.
By their numbers in this assay, from the lowest: compounds 1 and 3 (each within the scatter of the next); then compound 2.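

With the sulfonyl side held constant, the group on the carbonyl carbon is now seen on its own in this assay: the change to 1-methyl-1H-pyrazol-5-yl gives a number 28 percentage points lower from compound 2 to compound 3 (beyond the scatter). This position is therefore not indifferent to the acyl group, which the earlier pair could not show, since compound 1 and compound 2 differ in more than one place. The step changes heavy-atom count, ring count and hetero atoms together, and no measurement available here accounts for the loss.

The compounds shown leave open which part of the group leaving carries the higher number, and where a plain phenyl or an acetyl group would fall at this position. As far as these compounds go, whether the step holds with the sulfonyl group of compound 1 also stays open.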